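Replacing a dimethylphenyl ring with a methylaminophenyl ring

This account rests on a few compounds, and the source may have more. Where it says the series, first, only, none or still open, it means among the compounds named here.

Of the compounds shown here, two have been tested in a functional assay on the whole organism with Rattus norvegicus as the target, at a dose of 3 mg/kg by the oral route; a higher number here means a stronger effect of the compound at the dose given, a lower number a weaker effect. Compound 1 `CCCc1ccc(-c2cc(OC)cc(C(=O)Nc3nn[nH]n3)n2)cc1` gives 93%. Compound 2 `COc1cc(C(=O)Nc2nn[nH]n2)nc(-c2ccc(C)c(C)c2)c1` gives 82%, and in this assay compound 2 stands lowest of the two numbers, with compound 1 its nearest neighbour at a value higher by a margin beyond the usual scatter. For the measured compounds named here, no single-point step between measured compounds is available, so only these two values can be compared.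

Compound 3 `CNc1ccc(-c2cc(OC)cc(C(=O)Nc3nn[nH]n3)n2)cc1` has not yet been measured in this assay. It differs from compound 2 as follows: 4-(methylamino)phenyl in place of 3,4-dimethylphenyl on an aromatic carbon. Both measured compounds carry an alkyl-substituted phenyl ring and both give high inhibition, while compound 3 carries a ring bearing a hydrogen-bond donor and acceptor, a feature without precedent among the two measured compounds. The step of a number 4 percentage points lower from compound 2 to compound 3 (within the scatter) is therefore expected to be small, at most slightly downward and plausibly within the scatter. Compound 3 is estimated to give 78% in this assay, within a range from 45% to 95%.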

Compound 3, a percentage reported as inhibition, in the whole organism at one dose (the size of the read-out at that dose, not a potency): 79%
Estimate against measurement, compound 3: 1 percentage points below, within the range that was stated.
By their numbers in this assay, from the lowest: compounds 3 and 2 (each within the scatter of the next); then compound 1.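

In this assay the exchange of 3,4-dimethylphenyl for 4-(methylamino)phenyl gives a number 3 percentage points lower from compound 2 to compound 3 (within the scatter) and thereby shows that this position accepts a ring carrying a hydrogen-bond donor and acceptor, which the two alkyl-substituted compounds could not show. Set against the propyl group, the methylamino group gives a number 14 percentage points lower from compound 1 to compound 3 (beyond the scatter) as a modest step, so the ring substituent can still shift the read-out at this dose. Nothing measured here bears on why either step has its size.

The compounds shown leave open whether the hydrogen on the nitrogen matters, a question that 4-aminophenyl and 4-(dimethylamino)phenyl would address. They also leave open how a longer chain on that nitrogen, such as ethylamino, would read in this assay at this single oral dose.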